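Series notes: chlorobenzyl isomer swap and artery inhibition

The compounds below may be only part of what the source reports. "The series", "measured", "known", "first", "only" and "open" are said of these compounds alone.

Measured so far in a functional assay on the whole organism (artery, strain albino) with Rattus norvegicus as the target, with a stated time of 720 min, at a dose of 10 mg/kg by the oral route; a lower number here means less inhibition, a higher number more inhibition at the dose given (going by the name of the read-out):
compound 1, `CC1=C(C(=O)Nc2ccc([N+](=O)[O-])cc2)C(c2ccc(Br)cc2)N=C(SCc2cccc(Cl)c2)N1`, gives 2.6%
compound 2, `CC1=C(C(=O)Nc2ccc([N+](=O)[O-])cc2)C(c2ccc(Br)cc2)N=C(SCc2ccc(Cl)cc2)N1`, gives 29.4%
compound 3, `CC1=C(C(=O)Nc2ccc([N+](=O)[O-])cc2)C(c2cccc([N+](=O)[O-])c2)N=C(SCc2cccc(Cl)c2)N1`, gives 12.9%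

Compound 1 and compound 2 share one core and differ only by 4-chlorophenyl in place of 3-chlorophenyl on a saturated chain carbon bound to a sulfur. That change produced a number 26.8 percentage points higher from compound 1 to compound 2 (beyond the scatter) in this assay. Compound 3 carries a different core, the difference from compound 1 being (3-nitrophenyl in place of 4-bromophenyl on a saturated ring carbon); this gave a number 10.3 percentage points higher from compound 1 to compound 3 (beyond the scatter), so compound 3 stands between compound 1 and compound 2, with both gaps beyond the scatter.

Compound 4, `CC1=C(C(=O)Nc2ccc([N+](=O)[O-])cc2)C(c2cccc([N+](=O)[O-])c2)N=C(SCc2ccc(Cl)cc2)N1`, is not yet measured. It stands to compound 3 as compound 2 stands to compound 1: the difference is 4-chlorophenyl in place of 3-chlorophenyl on a saturated chain carbon bound to a sulfur, and the place line is the same word for word as in the earlier pair, so this is the same change, made on the core of compound 3 instead of the core of compound 1.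

Going by the values given here, only one earlier instance of the change is known, and only on the other core, so the expectation rests on a single step. Compound 4 is expected to lie higher than compound 3, because a number 26.8 percentage points higher from compound 1 to compound 2 (beyond the scatter) was the result of this change before; the step is estimated as a number 22.1 percentage points higher from compound 3 to compound 4 (beyond the scatter), set somewhat smaller than the earlier one since the core differs. Compound 4 is expected to give about 35% in this assay, with a range from 18% to 52%.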

Compound 4, a percentage reported as inhibition, in the whole organism at one dose (the size of the read-out at that dose, not a potency): 15.5%
For compound 4 the middle estimate is 19.5 percentage points above the measured one; measured number outside the range, below it.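

In this assay, 4-chlorophenyl in place of 3-chlorophenyl on a saturated chain carbon bound to a sulfur gives a number 2.6 percentage points higher from compound 3 to compound 4 (within the scatter), so on the core of compound 3 this change shows no readable gain, and its size does not carry over from the core of compound 1: the same change on two cores in this assay, a number 26.8 percentage points higher (beyond the scatter) from compound 1 to compound 2 and a number 2.6 percentage points higher (within the scatter) from compound 3 to compound 4, 24.2 percentage points apart, beyond the scatter of two such steps

Read from the other place, 3-nitrophenyl in place of 4-bromophenyl on a saturated ring carbon gives a number 13.9 percentage points lower from compound 2 to compound 4 (beyond the scatter), which runs opposite to the step of the same change among the 3-chlorobenzyl compounds: the same change on two cores in this assay, a number 10.3 percentage points higher (beyond the scatter) from compound 1 to compound 3 and a number 13.9 percentage points lower (beyond the scatter) from compound 2 to compound 4, 24.2 percentage points apart, beyond the scatter of two such steps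

Across these four compounds the two changes therefore do not act independently, and a step measured on one core is a poor guide to the same step on the other; this does not show why they interact, and with only two cores and one oral dose it says nothing about how the change would behave on any further core.

The compounds shown leave open whether the large step seen with 4-bromophenyl is specific to bromine or would also appear with a 4-chlorophenyl or 4-methoxyphenyl group on the saturated ring carbon. They also leave open whether a methoxy group or a fluorine in place of the chlorine on the benzyl group would follow either core's pattern.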